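Adding a Dicarboxypropyl Group to Compound 2

The source may report more compounds than this note shows. Statements on the series, on what has been measured and on what is new or still open speak of the compounds shown alone.

Measured in a functional assay on HeLa cells (Homo sapiens) for cytotoxicity, read by CCK-8 assay, with a stated time of 16 h; on this read-out lower numbers stand for stronger inhibition and higher numbers for weaker inhibition:
- Compound 1 `COc1ccc(C2=[N+]3C(=Nc4c(-c5ccccc5)c5c(n4[B-]3(F)F)-c3ccc(OCC(=O)O)cc3CC5)C(c3ccccc3)=C2I)cc1`: > 50000 nM
- Compound 2 `COc1ccc2c(c1)CCc1c(-c3ccccc3)c3n(c1-2)[B-](F)(F)[N+]1=C(c2ccc(OCC(=O)O)cc2)C(I)=C(c2ccccc2)C1=N3`: > 50000 nM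

Compound 1 gives > 50000 nM, which is a limit of the assay and not a number. Compound 2 likewise gives > 50000 nM, also a limit. Compound 3 `COc1ccc2c(c1)CCc1c(-c3ccccc3)c3n(c1-2)[B-](F)(F)[N+]1=C(c2ccc(OCC(=O)N[C@@H](CCC(=O)O)C(=O)O)cc2)C(I)=C(c2ccccc2)C1=N3` differs from compound 2 in one place: (1,3-dicarboxypropyl)amino in place of hydroxy on a carbonyl carbon. There, (1,3-dicarboxypropyl)amino stands in place of hydroxy on a carbonyl carbon. Within the data shown here, no measured step shows the effect of this change, so no step beyond the usual scatter is expected in this assay. The expected change is a number no higher from compound 2 to compound 3 (the limit leaves the size open). The estimate for compound 3 is 50000 nM, with an expected range of 25000 nM to 100000 nM.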

Compound 3, half-maximal inhibitory concentration in the HeLa assay: > 250000 nM
Compound 3: a limit, no number; the forecaster's own chance of this, stated with the estimate: 85%; at least 5.0-fold (0.69 log units) between middle value and limit.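

In the HeLa assay, compound 2 gives > 50000 nM, which is a limit and not a number. In the HeLa assay, compound 3 gives > 250000 nM, which is also a limit and not a number. No step can be read between these two compounds. The compounds shown leave open whether (1,3-dicarboxypropyl)amino in place of hydroxy changes cytotoxicity at all. In a physicochemical assay for lipophilicity (a lower number here means a more polar compound, a higher number a more lipophilic compound), compound 2 gives 0.92 and compound 3 gives -0.71.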